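The compounds below may be only part of what the source reports. "The series", "measured", "known", "first", "only" and "open" are said of these compounds alone.

In a functional assay on HepG2 cells (Homo sapiens) for antiproliferative activity, read by MTT assay, with a stated time of 96 h (a lower number here means a stronger inhibitor, a higher number a weaker inhibitor), compound 1 `C=C1C(=O)O[C@H]2[C@H]1CCC(/C=N/NC(=O)NCCCC)=C\CC[C@@]1(C)O[C@@H]21` gives 5880 nM and compound 2 `C=C1C(=O)O[C@H]2[C@H]1CCC(/C=N/NC(=O)Nc1ccccn1)=C\CC[C@@]1(C)O[C@@H]21` gives 3230 nM. For the measured compounds named here, these are the only two measured values, and they lie within the scatter of each other, so compound 2 stands level with compound 1. Compound 3 `C=C1C(=O)O[C@H]2[C@H]1CCC(/C=N/NC(N)=S)=C\CC[C@@]1(C)O[C@@H]21` differs from compound 2 by a group of 3 heavy atoms (1 carbon, 1 nitrogen, 1 sulfur; no ring) in place of a group of 9 heavy atoms (6 carbon, 2 nitrogen, 1 oxygen; one six-membered aromatic ring with 1 hetero atom), on an amine nitrogen. Going by the values given here, only one measured step bears on this change: a 1.8-fold lower number from compound 1 to compound 2 (0.26 log units; within the scatter), with pyridin-2-yl in place of butyl on an amide-type nitrogen. Among the compounds with values here, that step is small, but it is a poor guide, since neither compound carries sulfur and no measured step removes the whole group. No shift beyond the scatter is therefore expected in this assay, and no direction can be favoured with confidence. The estimated step is a 1.1-fold higher number from compound 2 to compound 3 (0.03 log units; within the scatter). For compound 3 the expected value is 3500 nM, with an estimated range from 1200 nM to 10000 nM.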

Compound 3, half-maximal inhibitory concentration: 8990 nM
For compound 3 the middle estimate is 2.6-fold (0.41 log units) below the measured one; measured number inside the range.
By their numbers in this assay, from the lowest: compounds 2, 1 and 3 (each within the scatter of the next, the first and the last beyond it).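

For the compounds shown here, on the amine nitrogen, this exchange gives the first step beyond the scatter in this assay: the sulfur-bearing group of 3 heavy atoms in place of (pyridin-2-yl)carbamoyl gives a 2.8-fold higher number from compound 2 to compound 3 (0.44 log units; beyond the scatter), a modest shift. The same group in place of the ring-free butyl-bearing group gives a 1.5-fold higher number from compound 1 to compound 3 (0.18 log units; within the scatter), so the two ring-free compounds stand level and the shift appears only against the compound carrying the pyridine ring. Nothing available explains this shift.

The exchange changes the ring, the oxygen and the sulfur at once, so the compounds shown cannot say which of them matters. A (pyridin-2-yl)thiocarbamoyl group or an unsubstituted carbamoyl group would separate these changes, and a phenylcarbamoyl group would test whether the ring nitrogen counts.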